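Compound 3: what one flat step can predict

The source may report more compounds than this note shows. Statements on the series, on what has been measured and on what is new or still open speak of the compounds shown alone.

Compound 1 `CCCCCCCCCCCCNCCN`: 1000 nM
Compound 2 `CCCCCCCCCCCCNCCN=C(N)N`: 1000 nM
Compound 3 `CCCCCCCCCCCCNCC(N)CCCN`: not yet measured

In a functional assay on HL-60 cells (Homo sapiens) for activation (a lower number here means that less compound is needed, a higher number that more compound is needed for the effect), compound 2 gives 1000 nM, level with compound 1 at the digits shown. Compound 3 differs from it by a group of 6 heavy atoms (4 carbon, 2 nitrogen; no ring) in place of a group of 5 heavy atoms (2 carbon, 3 nitrogen; no ring), on a saturated chain carbon bound to an amine nitrogen. The entering group is 1,4-diaminobutyl, and it sits on a saturated chain carbon bound to an amine nitrogen. Among the measured compounds shown here, only one measured step bears on this change: no change at the digits printed from compound 1 to compound 2 (within the scatter). That step lies within the scatter, so it offers no size or direction to carry forward. For the measured compounds named here, no measured compound carries the 1,4-diaminobutyl group, so the data cannot say what it does. No shift beyond the scatter is therefore expected in this assay, though the uncertainty is wide. The expected change is no change at the digits printed from compound 2 to compound 3 (within the scatter). For compound 3, the estimated value is 1000 nM, with an expected range from 300 nM to 3000 nM.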

Compound 3, half-maximal effective concentration: 1000 nM
Beside the measured number, compound 3's estimate shows no gap at the digits printed; the measured number falls inside the stated range.
By their numbers in this assay, from the lowest: compounds 1, 2 and 3 (each within the scatter of the next).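

In this assay, the 1,4-diaminobutyl group, on a saturated chain carbon bound to an amine nitrogen, now has a measured result (no change at the digits printed from compound 2 to compound 3 (within the scatter)). Compound 3 also shows what 3-aminopropyl in place of hydrogen does on this carbon, a swap that the earlier pair did not cover (no change at the digits printed from compound 1 to compound 3 (within the scatter)). Neither step goes beyond the scatter, so these three compounds stand level, and no measured evidence is at hand to explain this.

Still open, going by these compounds, is whether a carboxylic acid or a hydroxyl group on this same carbon would move the number beyond the scatter. The compounds shown also leave open whether a longer chain in place of 3-aminopropyl would do so.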